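The source may hold more compounds than are shown below. What is called first, only, known or untested is meant among the compounds shown, and "the series" means these compounds.

Working notes on the series, all in a functional assay on HeLa cells (Homo sapiens) for antiproliferative activity, read by MTT assay, with a stated time of 72 h; on this read-out higher numbers stand for weaker inhibition and lower numbers for stronger inhibition. Compound 1 `CC(C)/C=C/C(=O)Nc1cccc(Oc2nc(Nc3ccn(C)n3)nc3c2CSCC3)c1` gives 40100 nM and compound 2 `C/C=C/C(=O)Nc1cccc(Oc2nc(Nc3cccc(C#N)c3)nc3c2CSCC3)c1` gives 12800 nM while compound 3 `CC/C=C/C(=O)Nc1cccc(Oc2nc(Nc3cccc(C#N)c3)nc3c2CSCC3)c1` gives 31800 nM on the same read-out. Compound 3 stands level with compound 1 within the scatter, and its number is higher than that of compound 2. The next change leads to compound 4 `CC(C)/C=C/C(=O)Nc1cccc(Oc2nc(Nc3cccc(C#N)c3)nc3c2CSCC3)c1` and is methyl in place of hydrogen on a saturated chain carbon bound to a double-bonded chain carbon and a saturated chain carbon in the chain, ethyl to isopropyl. For the measured compounds named here, one measured step bears on it directly: a 2.5-fold higher number from compound 2 to compound 3 (0.40 log units; beyond the scatter) for the same kind of replacement, methyl in place of hydrogen on a saturated chain carbon, modest but beyond the scatter. Compound 4 also shares its (3-methylbut-1-en-1-yl)carbonyl with compound 1 at 40100 nM in a molecule that differs elsewhere. One step is thin support. A rise no larger than the earlier one is expected, an estimated 1.3-fold higher number from compound 3 to compound 4 (0.12 log units; within the scatter) in this assay that may well stay within the scatter. For compound 4 the estimated value is 42000 nM with an expected range of 16000 nM to 100000 nM on this read-out.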

Compound 4, half-maximal inhibitory concentration: 22800 nM
Compound 4: the middle estimate sits 1.8-fold (0.27 log units) above what was measured; measured number inside the range.
By their numbers in this assay, from the lowest: compounds 2, 4, 3 and 1 (each within the scatter of the next, the first and the last beyond it).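

The step of a 2.5-fold higher number from compound 2 to compound 3 (0.40 log units; beyond the scatter) in this assay is not repeated when methyl again replaces hydrogen on the saturated chain carbon, since a 1.4-fold lower number from compound 3 to compound 4 (0.14 log units; within the scatter) leaves the two compounds level within the scatter. Isopropyl in place of methyl on the double-bonded chain carbon gives a 1.8-fold higher number from compound 2 to compound 4 (0.25 log units; within the scatter) and also stays within the scatter, so the gap from compound 2 holds for the ethyl compound 3 but not for the isopropyl compound 4. With the (3-methylbut-1-en-1-yl)carbonyl held fixed, 3-cyanophenyl in place of 1-methyl-1H-pyrazol-3-yl on the nitrogen gives a 1.8-fold lower number from compound 1 to compound 4 (0.25 log units; within the scatter) and is likewise within the scatter.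

No evidence at hand accounts for these numbers. Going by these compounds, whether a tert-butyl group, a longer chain or an amine on this chain would stay in the same range remains open.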